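A few compounds are considered here, and "the series" means these few. Any claim that something is new, unique, unknown or untested is made for them only; others in the source may bear on it.

Measured in a functional assay on CCRF-CEM cells (Homo sapiens) for inhibition, read by sulforhodamine B assay, with a stated time of 48 h; on this read-out lower numbers stand for stronger inhibition of growth and higher numbers for weaker inhibition of growth:
compound 1 `COc1cc(-c2nn(-c3cccc(NC(=O)c4cccc(C(F)(F)F)c4)c3)cc2-c2ccncc2)ccc1Cl` — a limit, > 50000 nM
compound 2 `COc1cc(-c2nn(-c3cccc(NC(=O)c4ccc(Cl)c(C(F)(F)F)c4)c3)cc2-c2ccncc2)ccc1Cl` — a limit, > 32500 nM
compound 3 `COc1cc(-c2nn(-c3cccc(NC(=O)Nc4ccc(Cl)c(C(F)(F)F)c4)c3)cc2-c2ccncc2)ccc1Cl` — a limit, > 32500 nM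

Compound 3 stands at a limit of this assay, as do the other two; no number separates any of them, and the limit of > 32500 nM in this assay, at which 2 of the 3 values shown sit, together with the limit of > 50000 nM in this assay, at which 1 of the 3 values shown sits, is all that the three values show. Compound 4 `COc1cc(-c2nn(-c3cccc(NC(=O)c4ccccc4)c3)cc2-c2ccncc2)ccc1Cl` is not yet measured. The change is phenyl in place of (4-chloro-3-(trifluoromethyl)phenyl)amino on a carbonyl carbon. The steps that touch the same carbonyl carbon, a step that the two limits leave unreadable from compound 1 to compound 3 and a step that the two limits leave unreadable from compound 2 to compound 3, are unreadable between limits, as is a step that the two limits leave unreadable from compound 1 to compound 2. No readable step therefore supports any direction for compound 4, and the expectation is that compound 4 also sits at a limit. For compound 4 the estimated value is 50000 nM, within 20000 nM to 100000 nM. The expected step that the limit leaves unreadable from compound 3 to compound 4 is thus none beyond the scatter.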

Compound 4, concentration for total growth inhibition: > 100000 nM
Compound 4 was reported as a limit; the forecaster's own chance of this, stated with the estimate: 85%; middle value at least 2.0-fold (0.30 log units) away from the limit.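

Among the compounds shown here, compound 4 sits at a limit, as do compound 1, compound 2 and compound 3, so no step among them can be read in this assay. The compounds shown leave open whether any change on the carbonyl carbon alters growth inhibition.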